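The compounds below may be only part of what the source reports. "The series", "measured", "known", "first", "only" and "open" are said of these compounds alone.

Measured in an ADME assay on Vero cells (Chlorocebus sabaeus) for cytotoxicity, read by MTT assay, with a stated time of 72 h; on this read-out lower numbers stand for an effect already at smaller amounts and higher numbers for an effect only at larger amounts of compound:
Compound 1 `O=C(Nc1nc(-c2ccccn2)cs1)c1cccc(OCc2ccccc2)c1` gives 14400 nM
Compound 2 `O=C(Nc1nc(-c2ccccn2)cs1)c1ccc(OCc2ccccc2)cc1` gives 2300 nM
Compound 3 `CC(=O)c1ccccc1C(=O)Nc1nc(-c2ccccn2)cs1` gives 86700 nM

Compound 2 has the lowest number of the three, and compound 1 and compound 3 both lie beyond the scatter from it. Compound 4 `CC(=O)c1ccc(C(=O)Nc2nc(-c3ccccn3)cs2)cc1`, not yet measured, has acetyl in place of benzyloxy on an aromatic carbon, para to a large group acetyl in place of benzyloxy on an aromatic carbon in comparison with compound 2. Within the data shown here, no measured pair shows this change directly. Among the measured compounds shown here, the only guide is compound 3, which also carries an acetyl and gives 86700 nM as the highest number. The step expected in this assay is therefore a rise beyond the scatter (estimated an 11-fold higher number from compound 2 to compound 4 (1.04 log units; beyond the scatter)). Compound 4 is expected to read 25000 nM (estimated range 7000 nM to 80000 nM).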

Compound 4, half-maximal effective concentration: 10500 nM
For compound 4 the middle estimate is 2.4-fold (0.38 log units) above the measured one; low and high end bracket the measured number.
By their numbers in this assay, from the lowest: compound 2; then compounds 4 and 1 (each within the scatter of the next); then compound 3.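

In this assay, acetyl in place of benzyloxy on an aromatic carbon, para to a large group, brings a 4.6-fold higher number from compound 2 to compound 4 (0.66 log units; beyond the scatter) as a modest step. Among these compounds, this is the first direct reading of a change at this position, and it shows that the number rises when the benzyloxy and its aromatic ring leave. No evidence is available that explains this step.

From the compounds shown here alone, whether an amine, a carboxylic acid or a longer chain at this position would read closer to compound 2 or to compound 4 remains open.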